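Amide substituent change on a non-cytotoxic core

A few compounds are considered here, and "the series" means these few. Any claim that something is new, unique, unknown or untested is made for them only; others in the source may bear on it.

Compound 1 `C=CC1=C(C(=O)NCc2ccc(Cl)cc2)C(c2ccc(OC)cc2)OC1` was tested in a functional assay on HeLa cells (Homo sapiens) for cytotoxicity, read by MTT assay, with a stated time of 24 h; a lower number here means a stronger inhibitor, a higher number a weaker inhibitor. In this assay compound 1 gives only a limit, > 100000 nM, not a number. Compound 2 `C=CC1=C(C(=O)NC(C)(C)C)C(c2ccc(OC)cc2)OC1` likewise shows only the limit > 100000 nM in this assay. Compound 3 `C=CC1=C(C(=O)NCc2ccccc2)C(c2ccc(Cl)c(Cl)c2)OC1` also stops at the limit > 100000 nM. Among the compounds with values here, the single step between measured neighbours, a step that the two limits leave unreadable from compound 1 to compound 2, is therefore unreadable. Within the data shown here, all three values sit at the same limit (the limit of > 100000 nM in this assay, at which 3 of the 3 values shown sit), so no step of any size or direction has yet been seen. Compound 4 `C=CC1=C(C(=O)Nc2ccccc2OC)C(c2ccc(OC)cc2)OC1` differs from compound 1 in one place (2-methoxyphenyl in place of 4-chlorobenzyl on an amide-type nitrogen). With every measured neighbour at the limit, the step from compound 1 to compound 4 is expected to stay small, a step that the limit leaves unreadable from compound 1 to compound 4. Compound 4 is therefore estimated to give 150000 nM, with a range from 50000 nM to 500000 nM, most likely again reported only as a limit.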

Compound 4, half-maximal inhibitory concentration: > 100000 nM
Compound 4: no number, only a limit; the forecaster's own chance of this, stated with the estimate: 85%; the middle value lies beyond the limit too.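

Compound 4 also stops at a limit, so its steps from compound 1 and compound 2 cannot be read. Which change to the shared core would give a real number in this assay stays open, as every value shown is a limit: the limit of > 100000 nM in this assay, at which 4 of the 4 values shown sit.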